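This account rests on a few compounds, and the source may have more. Where it says the series, first, only, none or still open, it means among the compounds named here.

Measured compounds:
compound 1, `O=[N+]([O-])c1ccc(Nc2ccc(N3CC4CC(C3)N4)cn2)cc1`: 1.76 nM
compound 2, `Fc1ccc(Nc2ccc(N3CC4CC(C3)N4)nn2)cc1`: 868 nM

Compound 1 has the lowest of the two numbers recorded in an assay on cell membranes for displacement of a labelled ligand from Neuronal acetylcholine receptor; alpha4/beta2 (Rattus norvegicus); a higher number here means a weaker inhibitor, a lower number a stronger inhibitor; compound 2 stands far higher, beyond the scatter, but the two compounds differ in more than one place, so no single step can be read from them. Compound 3, `Cc1ccc(Nc2ccc(N3CC4CC(C3)N4)cn2)cc1`, is not yet measured. It differs from compound 1 as follows: methyl in place of nitro on an aromatic carbon. Among the measured compounds shown here, no measured step of this kind exists; a moderate loss is nevertheless expected in this assay, beyond the scatter, giving an expected 4.5-fold higher number from compound 1 to compound 3 (0.66 log units; beyond the scatter). For compound 3 the estimate is 8 nM, with a range from 2 nM to 40 nM.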

Compound 3, inhibition constant: 52.1 nM
Compound 3: middle estimate off by 6.5-fold (0.81 log units), on the low side, and the stated range ends below it.
By their numbers in this assay, from the lowest: compound 1; then compound 3; then compound 2.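

In this assay, among the compounds shown here, methyl in place of nitro on this aromatic carbon gives a 30-fold higher number from compound 1 to compound 3 (1.47 log units; beyond the scatter) as the first single-place step. The group para to a large group on the shared core therefore strongly affects the value, with nitro the better of the two groups tested here. No measurement available here explains the step.

Two groups at one position define no trend. From the compounds shown here alone, whether an amine, a nitrile or a chlorine atom at this carbon would stand nearer compound 1 or compound 3 remains open.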